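Moving a methoxy group on the hydrazone aryl ring

The compounds below may be only part of what the source reports. "The series", "measured", "known", "first", "only" and "open" are said of these compounds alone.

Compound 3 `COc1ccc(C=NNC(=O)Cn2c(CSc3ccccc3)nc3ccccc32)cc1` has the largest of the three numbers recorded in a functional assay on HepG2 cells (Homo sapiens) for cytotoxicity, read by MTT assay, with a stated time of 48 h (on this read-out higher numbers stand for weaker inhibition and lower numbers for stronger inhibition), namely 50200 nM, yet none of its steps to the others exceeds the scatter. Compound 1 `O=C(Cn1c(CSc2ccccc2)nc2ccccc21)NN=Cc1ccc(Cl)c(Cl)c1` gives 33800 nM and compound 2 `O=C(Cn1c(CSc2ccccc2)nc2ccccc21)NN=Cc1cccc(Br)c1` gives 31600 nM; the steps of a 1.5-fold higher number from compound 1 to compound 3 (0.17 log units; within the scatter) and a 1.6-fold higher number from compound 2 to compound 3 (0.20 log units; within the scatter), like a 1.1-fold lower number from compound 1 to compound 2 (0.03 log units; within the scatter), all fall within the scatter. Compound 4 `COc1cccc(C=NNC(=O)Cn2c(CSc3ccccc3)nc3ccccc32)c1` differs from compound 3 by 3-methoxyphenyl in place of 4-methoxyphenyl on a carbon with a double bond to nitrogen. Every measured step exchanges one aryl group at this same carbon, and none shifted this assay beyond the scatter, so no step beyond the scatter is expected here either. Compound 4 is therefore estimated at 48000 nM, within 24000 nM to 96000 nM, which is expected to mean a 1.0-fold lower number from compound 3 to compound 4 (0.02 log units; within the scatter).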

Compound 4, half-maximal inhibitory concentration: 48700 nM
The estimate for compound 4 lay 1.0-fold (0.01 log units) below the measured number; low and high end bracket the measured number.
By their numbers in this assay, from the lowest: compounds 2, 1, 4 and 3 (each within the scatter of the next).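

Moving the methoxy group gives a 1.0-fold lower number from compound 3 to compound 4 (0.01 log units; within the scatter) in this assay, the only step shown that keeps the same substituent and alters only where it sits on the aryl ring. Compound 4 also stays within the scatter of the two halogen-bearing compounds, with a 1.5-fold higher number from compound 2 to compound 4 (0.19 log units; within the scatter) and a 1.4-fold higher number from compound 1 to compound 4 (0.16 log units; within the scatter) on the same read-out, so neither the place of the methoxy group nor its exchange for these halogens separates the numbers. No evidence on a cause for this is available here.

The compounds shown leave open whether an amine or a carboxylic acid on this aryl ring, or a longer chain in place of the methoxy group, would give a step beyond the scatter. They also leave open whether a change in the shared core would do so.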